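The source may hold more compounds than are shown below. What is called first, only, known or untested is meant among the compounds shown, and "the series" means these compounds.

Two acrylamide sulfonamides have been measured in a functional assay on B16-F10 cells (Mus musculus) for antiproliferative activity, read by ELISA and MTT assay, with a stated time of 48 h; on this read-out lower numbers stand for stronger inhibition and higher numbers for weaker inhibition. Compound 1, `COc1ccc(/C=C/C(=O)NS(=O)(=O)c2ccc(F)cc2)cc1`, gives 5.1 ug/mL in this assay. Compound 2, `CN(C)c1ccc(/C=C/C(=O)NS(=O)(=O)c2ccccc2)cc1`, gives 2.3 ug/mL in this assay, the lowest of the two numbers, and the gap to compound 1 lies beyond the scatter. The two measured compounds differ in two places at once, so what the two values show cannot be divided between those places.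

Compound 3, `CN(C)c1ccc(/C=C/C(=O)NS(=O)(=O)c2ccc(F)cc2)cc1`, has not yet been measured. It differs from compound 2 in one place: fluoro in place of hydrogen on an aromatic carbon, on an aromatic carbon of a six-membered aromatic ring of carbon only, para to a large group. Going by the values given here, no measured pair shows this exchange alone, so the expected step from compound 2 to compound 3 in this assay, no change at the digits printed from compound 2 to compound 3 (within the scatter), is estimated to be none beyond the scatter, with no clear direction. On that basis compound 3 is expected to give about 2.3 ug/mL in this assay, within a range from 1.2 ug/mL to 4.6 ug/mL.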

Compound 3, half-maximal inhibitory concentration: 2.3 ug/mL
Beside the measured number, compound 3's estimate shows no gap at the digits printed; measured number inside the range.
By their numbers in this assay, from the lowest: compounds 2 and 3 (each within the scatter of the next); then compound 1.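

In this assay, fluoro in place of hydrogen on an aromatic carbon, para to a large group, gives no change at the digits printed from compound 2 to compound 3 (within the scatter), so with dimethylamino present, phenyl and 4-fluorophenyl cannot be told apart on this read-out. The other exchange, dimethylamino in place of methoxy on an aromatic carbon, gives a 2.2-fold lower number from compound 1 to compound 3 (0.35 log units; beyond the scatter), which isolates in a single-place comparison a step beyond the scatter, though a modest one, with 4-fluorophenyl held constant. Nothing shown here accounts for either step.

The compounds shown leave open whether fluoro would again make no difference beyond the scatter with methoxy in place of dimethylamino, and whether the phenyl position would tolerate a larger replacement for hydrogen, such as chloro, trifluoromethyl or a carboxylic acid. They also leave open how far the step seen at the other position extends to other groups there, such as a primary amine, a hydroxyl or a longer diethylamino group.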